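Carbonyl for thiocarbonyl on the ring nitrogen of the core

The compounds below may be only part of what the source reports. "The series", "measured", "known", "first", "only" and "open" are said of these compounds alone.

Measured compounds:
compound 1 `NC(=O)c1c(NC(=O)c2ccc(C(F)(F)F)cc2)sc2c1CCN(Cc1ccc(Cl)cc1)C2` — > 50000 nM
compound 2 `NC(=O)c1c(NC(=O)c2ccc(C(F)(F)F)cc2)sc2c1CCN(C(=S)Nc1ccccc1Cl)C2` — 44000 nM

In a functional assay on HeLa cells (Homo sapiens) for antiproliferative activity, with a stated time of 24 h (on this read-out higher numbers stand for weaker inhibition and lower numbers for stronger inhibition), compound 1 reaches only > 50000 nM, a limit of the assay and not a number. In this assay, among the compounds with values here, compound 2 gives 44000 nM, the only number in the set. Within the data shown here, the single measured step, an at least 1.1-fold lower number from compound 1 to compound 2 (0.05 log units; that floor lies within the scatter), is bounded by the limit of > 50000 nM in this assay, at which 1 of the 2 values shown sits, and does not rise above the scatter.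

Compound 3 `NC(=O)c1c(NC(=O)c2ccc(C(F)(F)F)cc2)sc2c1CCN(C(=O)Nc1ccccc1Cl)C2` differs from compound 2 by a group of 10 heavy atoms (7 carbon, 1 nitrogen, 1 oxygen, 1 chlorine; one six-membered aromatic ring of carbon only) in place of a group of 10 heavy atoms (7 carbon, 1 nitrogen, 1 sulfur, 1 chlorine; one six-membered aromatic ring of carbon only), on an amine nitrogen in a ring. Among the measured compounds shown here, no measured step exchanges these two groups; the one step recorded touches the same ring nitrogen but swaps a different pair of groups, and it stayed within the scatter. Nothing in the set therefore points to a shift beyond the scatter in this assay, in either direction. Compound 3 is expected at 45000 nM, between 20000 nM and 100000 nM, an estimated step of a 1.0-fold higher number from compound 2 to compound 3 (0.01 log units; within the scatter); a reading that is again only a limit is a real possibility.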

Compound 3, half-maximal inhibitory concentration: > 50000 nM
Compound 3 ended at the assay's limit (the forecaster's own chance of this, stated with the estimate: 40%); at least 1.1-fold (0.04 log units) between middle value and limit.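

On the amine nitrogen in a ring, (2-chlorophenyl)carbamoyl in place of its sulfur-bearing counterpart gives, in this assay, an at least 1.1-fold higher number from compound 2 to compound 3 (0.05 log units; that floor lies within the scatter); this exchange of sulfur for oxygen therefore shows no step beyond the scatter, although the true size stays hidden behind a limit. The step from compound 1 to compound 3 cannot be read. The picture at this position now rests mostly on limits: the limit of > 50000 nM in this assay, at which 2 of the 3 values shown sit.

As far as these compounds go, whether any group on this ring nitrogen can bring the number clearly down in this assay stays open, and an acetyl or a methanesulfonyl group there would test this. Equally open, from the compounds shown here alone, is whether a nitrile or a methoxy group in place of the trifluoromethyl group shared by all three compounds would change the reading.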